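The source may hold more compounds than are shown below. What is called first, only, known or untested is meant among the compounds shown, and "the series" means these compounds.

Within the data shown here, compound 1, `O=C(CSC(=S)N[C@H]1CCOC1=O)Nc1ccc(Cl)cc1`, is the only member of this small set for which a number rather than a limit has been obtained in a functional assay on MCF7 cells (Homo sapiens) for cytotoxicity, read by MTT assay, with a stated time of 72 h (on this read-out lower numbers stand for stronger inhibition and higher numbers for weaker inhibition), where compound 1 gives 50300 nM. Its companion compound 2, `CCCCCCSC(=S)N[C@H]1CCOC1=O`, carries a hexyl chain in place of the anilide arm. In this assay compound 2 returns only a limit, > 128000 nM, so no number for it is known. Among the measured compounds shown here, that result is noted as the limit of > 128000 nM in this assay, at which 1 of the 2 values shown sits, and with one number and one limit the set offers no measured step between any two compounds.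

The unmeasured compound 3, `O=C(CSC(=S)N[C@H]1CCOC1=O)Nc1ccc(C(=O)/C=C/c2ccccc2)cc1`, differs from compound 1 in a single place: (2-phenylethenyl)carbonyl in place of chloro on an aromatic carbon. The new group sits on an aromatic carbon of a six-membered aromatic ring of carbon only, para to a large group.

With no measured step to lean on, the direction of the change in this assay can only be expected, not inferred from shown data. The writer expects a moderate gain in inhibition, that is, a step toward lower numbers for compound 3, of a size given by a 3.4-fold lower number from compound 1 to compound 3 (0.53 log units; beyond the scatter). For compound 3 the expected value in this assay is therefore 15000 nM, with a range from 4000 nM to 60000 nM.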

Compound 3, half-maximal inhibitory concentration: 44300 nM
Estimate against measurement, compound 3: 3.0-fold (0.47 log units) below, within the range that was stated.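

At this position, on an aromatic carbon para to a large group, replacing chloro with (2-phenylethenyl)carbonyl gives a 1.1-fold lower number from compound 1 to compound 3 (0.06 log units; within the scatter) in this assay. Among these compounds, this is the first measured step in the set, and it shows that a single atom can give way to a group of 10 heavy atoms, carrying its own six-membered aromatic ring, 2 double bonds outside aromatic rings and a hydrogen-bond acceptor, without the read-out separating the two compounds. Among the compounds shown here, the only other compound with a different arm, compound 2, still stands as a limit and not a number, so this step remains the only measured comparison: the limit of > 128000 nM in this assay, at which 1 of the 3 values shown sits.

The compounds shown leave open whether anything at this position can move the number beyond the scatter, for instance an amine, a carboxylic acid or a methoxy group in place of chloro. They also leave open whether the carbon-carbon double bond of the new group matters at all, a question that the saturated 3-phenylpropanoyl group could address, and whether the flat result from this single step would hold for other groups of similar size.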